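This account rests on a few compounds, and the source may have more. Where it says the series, first, only, none or still open, it means among the compounds named here.

Compound 1 `COC(=O)/C(=C\c1ccc(OC(=O)c2ccc(OC)c(OC)c2)cc1)Sc1ccnc2cc(Cl)ccc12` gives 8290 nM in a functional assay on Jurkat E6.1 cells (Homo sapiens) for cytotoxicity, read by MTT assay, with a stated time of 24 h; on this read-out lower numbers stand for stronger inhibition and higher numbers for weaker inhibition. Compound 2 `COC(=O)/C(=C\c1ccc(OC(=O)c2ccc(OC)cc2OC)cc1)Sc1ccnc2cc(Cl)ccc12` gives 10200 nM.

On the numbers shown, compound 2 stands together with compound 1, the step of a 1.2-fold higher number from compound 1 to compound 2 (0.09 log units; within the scatter) lying within the scatter. Compound 3 `COC(=O)/C(=C\c1ccc(OC(=O)c2cc(OC)cc(OC)c2OC)cc1)Sc1ccnc2cc(Cl)ccc12` differs from compound 2 by 2,3,5-trimethoxyphenyl in place of 2,4-dimethoxyphenyl on a carbonyl carbon. Within the data shown here, the only step that bears on this change is a 1.2-fold higher number from compound 1 to compound 2 (0.09 log units; within the scatter), which stayed within the scatter, so in this assay no step beyond the scatter is expected, a 1.0-fold lower number from compound 2 to compound 3 (0.01 log units; within the scatter) being the expected size. Compound 3 is therefore estimated at 10000 nM, with a range from 4500 nM to 22000 nM.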

Compound 3, half-maximal inhibitory concentration: 15600 nM
Estimate against measurement, compound 3: 1.6-fold (0.19 log units) below; low and high end bracket the measured number.
By their numbers in this assay, from the lowest: compounds 1, 2 and 3 (each within the scatter of the next).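

The step to 2,3,5-trimethoxyphenyl on the carbonyl carbon is a 1.5-fold higher number from compound 2 to compound 3 (0.18 log units; within the scatter) and, starting from the 3,4-dimethoxyphenyl group, a 1.9-fold higher number from compound 1 to compound 3 (0.27 log units; within the scatter) as well. All three compounds therefore stand together, and this position takes the 2,3,5-trimethoxyphenyl group with no step beyond the scatter. Nothing measured accounts for these small differences. The compounds shown carry only methoxy-bearing phenyl groups at this place, so what an unsubstituted phenyl, an amine or a carboxylic acid would do there remains open.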